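Moving a trifluoromethyl group on a sulfonyl-linked phenyl

A few compounds are considered here, and "the series" means these few. Any claim that something is new, unique, unknown or untested is made for them only; others in the source may bear on it.

Four related amides share one core and differ only in the ring attached to a sulfonyl sulfur. Compound 1 `Cn1c(C(=O)NCc2ccc(S(=O)(=O)c3ccccc3)cc2)cc2ccncc21` was tested in an ADME assay on microsomes from liver (Mus musculus) for metabolic stability, read by LC-MS, with a stated time of 30 min, tested at 1 uM (a higher number here means that more of the compound is left, a lower number that less of the compound is left), and gave "below limit of detection" (no number reported), so no number is available for it. Compound 2 `O=C(NCc1ccc(S(=O)(=O)c2ccc(F)c(F)c2)cc1)c1cc2cnccc2[nH]1` gives 58%, and compound 3 `O=C(NCc1ccc(S(=O)(=O)c2ccccc2C(F)(F)F)cc1)c1cc2cnccc2[nH]1` gives 41%, the lower of the two numbers shown. For the measured compounds named here, the only measured step is a number 17 percentage points lower from compound 2 to compound 3 (beyond the scatter), and it exchanges one ring for a differently substituted one. Compound 4 `O=C(NCc1ccc(S(=O)(=O)c2cccc(C(F)(F)F)c2)cc1)c1cc2cnccc2[nH]1` differs from compound 3 by 3-(trifluoromethyl)phenyl in place of 2-(trifluoromethyl)phenyl on a sulfonyl sulfur. Going by the values given here, no measured step bears directly on this rearrangement, so no change beyond the scatter is expected, and compound 4 is estimated at 45%, between 25% and 65%, a step of a number 4 percentage points higher from compound 3 to compound 4 (within the scatter).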

Compound 4, percent of the compound remaining: 49%
Compound 4: middle estimate off by 4 percentage points, on the low side; the range from low to high includes it.
By their numbers in this assay, from the lowest: compounds 3, 4 and 2 (each within the scatter of the next, the first and the last beyond it).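

Moving the trifluoromethyl group on the ring gives a number 8 percentage points higher from compound 3 to compound 4 (within the scatter), so in this assay this rearrangement on a sulfonyl sulfur cannot be told apart from ordinary repeat variation. Putting 3-(trifluoromethyl)phenyl in place of 3,4-difluorophenyl gives a number 9 percentage points lower from compound 2 to compound 4 (within the scatter), so among these rings only 2-(trifluoromethyl)phenyl stands clearly apart from the 3,4-difluorophenyl of compound 2. Nothing available here offers an explanation for these numbers. Still open, on these data alone, is how a phenyl ring carrying an amine or a carboxylic acid at this place would fare.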